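From compound 3 to compound 4: a chloro leaves

This account rests on a few compounds, and the source may have more. Where it says the series, first, only, none or still open, it means among the compounds named here.

In a functional assay on HeLa cells (Homo sapiens) for cytotoxicity, read by sulforhodamine B assay, with a stated time of 48 h (a lower number here means a stronger inhibitor, a higher number a weaker inhibitor), compound 1 `O=C(c1cccnc1)c1ccccc1O` gives 33000 nM. Compound 2 `C=CCOc1c(Cl)cccc1C(=O)c1cccnc1` gives 100000 nM in this assay. Going by these compounds, compound 3 `O=C(c1cccnc1)c1cc(Cl)cc(Cl)c1O` gives > 100000 nM, which is a limit of the assay and not a number, so its exact place on the scale is unknown.

Compound 4 `O=C(c1cccnc1)c1cccc(Cl)c1O` differs from compound 3 by hydrogen in place of chloro on an aromatic carbon, para to a hydroxy group. For the measured compounds named here, no measured pair isolates this change, so any expectation rests on indirect comparison. With the chloro gone, compound 4 comes structurally closer to compound 1, at 33000 nM. A moderate step toward stronger inhibition in this assay is therefore expected, probably beyond the scatter, though a reading that again reaches the limit cannot be excluded. The expected change is an at least 2.0-fold lower number from compound 3 to compound 4 (0.30 log units; that floor lies within the scatter). Compound 4 is estimated at 50000 nM, with an expected range of 20000 nM to 100000 nM.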

Compound 4, half-maximal inhibitory concentration: 21000 nM
Estimate against measurement, compound 4: 2.4-fold (0.38 log units) above, within the range that was stated.
By their numbers in this assay, from the lowest: compounds 4 and 1 (each within the scatter of the next); then compound 2.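

In this assay, the chloro para to a hydroxy group now has a direct reading, with hydrogen in its place: an at least 4.7-fold lower number from compound 3 to compound 4 (0.67 log units; beyond the scatter). Compound 3 carries a limit of the assay and not a number, so this step gives only a floor: the limit of > 100000 nM in this assay, at which 1 of the 4 values shown sits. The chloro that compound 4 keeps does not separate it from compound 1, as a 1.6-fold lower number from compound 1 to compound 4 (0.20 log units; within the scatter) shows, whereas hydrogen in place of allyl on the oxygen gives a step beyond the scatter, a 4.8-fold lower number from compound 2 to compound 4 (0.68 log units; beyond the scatter).

Still open, going by these compounds, is whether an amine or a methoxy group in place of the chloro para to the hydroxy group would also give a number clear of the limit. Also open, on these data alone, is whether a methyl group on the oxygen would read like the allyl of compound 2.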